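Urea series: aryl swap on a second linker

This account rests on a few compounds, and the source may have more. Where it says the series, first, only, none or still open, it means among the compounds named here.

Measured so far:
- compound 1, `CC(NC(=O)C#Cc1ccc(NC(=O)Nc2cc(C(F)(F)F)ccc2Cl)cc1)c1ccccc1`: 30500 nM
- compound 2, `CC(NC(=O)C#Cc1ccc(NC(=O)Nc2ccc(Cl)c(C(F)(F)F)c2)cc1)c1ccccc1`: 16800 nM
- compound 3, `CC(NC(=O)/C=C/Oc1ccc(NC(=O)Nc2cc(C(F)(F)F)ccc2Cl)cc1)c1ccccc1`: 16000 nM

All three were read in a functional assay on A-375 cells (Homo sapiens) for inhibition, read by MTT assay, with a stated time of 120 h; a lower number here means a stronger inhibitor, a higher number a weaker inhibitor. Compound 1 and compound 2 share one core; compound 3 and the unmeasured compound 4, `CC(NC(=O)/C=C/Oc1ccc(NC(=O)Nc2ccc(Cl)c(C(F)(F)F)c2)cc1)c1ccccc1`, share another. How the two cores differ is not broken down here.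

Among the measured compounds shown here, the one change that recurs is 4-chloro-3-(trifluoromethyl)phenyl in place of 2-chloro-5-(trifluoromethyl)phenyl on an amide-type nitrogen. In this assay it gave a 1.8-fold lower number from compound 1 to compound 2 (0.26 log units; within the scatter), a shift that stays within the scatter of repeated readings. The same change, (4-chloro-3-(trifluoromethyl)phenyl in place of 2-chloro-5-(trifluoromethyl)phenyl on an amide-type nitrogen), is made on the core of compound 3 to give compound 4, and the place of the change is described in the same words for both pairs.

Compound 3 sits near compound 2 in this assay, the two values being within the scatter of each other; compound 1 is the only one of the three whose number lies somewhat apart, and that gap too is within the scatter.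

Given that compound 1 to compound 2 moved by a 1.8-fold lower number from compound 1 to compound 2 (0.26 log units; within the scatter), the step from compound 3 to compound 4 is expected to be of similar size, a 1.6-fold lower number from compound 3 to compound 4 (0.20 log units; within the scatter). Compound 4 is therefore estimated at 10000 nM in this assay, with a range of 4000 nM to 25000 nM. This rests on a single measured precedent, so the estimate is loose.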

Compound 4, half-maximal inhibitory concentration: 20700 nM
For compound 4 the middle estimate is 2.1-fold (0.32 log units) below the measured one, and the stated range covers the measured number.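

In this assay, 4-chloro-3-(trifluoromethyl)phenyl in place of 2-chloro-5-(trifluoromethyl)phenyl on the core of compound 3 gives a 1.3-fold higher number from compound 3 to compound 4 (0.11 log units; within the scatter). Set beside the same swap on the core of compound 1, the two steps do not separate from each other: the same change on two cores in this assay, a 1.8-fold lower number (0.26 log units; within the scatter) from compound 1 to compound 2 and a 1.3-fold higher number (0.11 log units; within the scatter) from compound 3 to compound 4, 2.3-fold (0.37 log units) apart, within the scatter of two such steps. This shows that, on these two cores, the swap produces no shift that stands clear of the scatter, and that the two pairs give no sign of the cores responding differently; it does not show that any real effect of the swap carries from one core to the other, since two small steps offer no such effect to follow, and a difference between the cores too small to exceed the scatter cannot be ruled out.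

All the aryl groups shown on the urea carry chlorine and trifluoromethyl, so it remains open whether a nitrile, a methoxy group or a dimethylamino group on that ring would move the number beyond the scatter. Also open, as far as these compounds go, is what a carboxylic acid, a tertiary amine or a longer chain would do at the amide end of either core in this assay.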